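A few compounds are considered here, and "the series" means these few. Any claim that something is new, unique, unknown or untested is made for them only; others in the source may bear on it.

Of the compounds shown here, three have been measured in a functional assay on MDA-MB-231 cells (Homo sapiens) for antiproliferative activity, read by MTT assay, with a stated time of 48 h; a lower number here means a stronger inhibitor, a higher number a weaker inhibitor. Compound 1 `C#Cc1cccc(Nc2ncnc3cc(NC(=O)/C=C/c4ccccc4)sc23)c1` gives 2340 nM. Compound 2 `O=C(/C=C/c1ccc(O)cc1)Nc1cc2c(Nc3ccc(Cl)c(Cl)c3)ncnc2s1` gives 1980 nM, which lies within the usual scatter of compound 1. Compound 3 `O=C(/C=C/c1ccccc1)Nc1cc2c(Nc3ccc(F)c(Cl)c3)ncnc2s1` gives 7600 nM, a number clearly higher than that of compound 1, so compound 1 stands at the stronger end of this small set, level with compound 2.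

Compound 4 `O=C(/C=C/c1ccccc1)Nc1cc2ncnc(Nc3cc(Cl)cc(Cl)c3)c2s1` keeps the core of compound 1 and changes one group: 3,5-dichlorophenyl in place of 3-ethynylphenyl on a nitrogen on an aromatic ring. Put simply, 3,5-dichlorophenyl sits in place of 3-ethynylphenyl on a nitrogen on an aromatic ring. Within the data shown here, no measured pair differs in only one place, so there is no direct guide to this swap. Chlorine-bearing rings also appear in compound 2 at 1980 nM and compound 3 at 7600 nM, though on a different core, and the expectation stays within that span. The estimated step of a 1.3-fold higher number from compound 1 to compound 4 (0.11 log units; within the scatter) is small and is expected to stay within the scatter. The expected value for compound 4 is 3000 nM, with an estimated range of 1100 nM to 8000 nM.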

Compound 4, half-maximal inhibitory concentration: 1000 nM
For compound 4 the middle estimate is 3.0-fold (0.48 log units) above the measured one; measured number below the stated range.
By their numbers in this assay, from the lowest: compounds 4, 2 and 1 (each within the scatter of the next, the first and the last beyond it); then compound 3.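

Among these compounds, this is the first pair in the set that differs in one place only, so the group on a nitrogen on an aromatic ring can now be judged by itself: in this assay, 3,5-dichlorophenyl in place of 3-ethynylphenyl gives a 2.3-fold lower number from compound 1 to compound 4 (0.37 log units; beyond the scatter), a modest step. The number at this position therefore responds to the swap, even though the two groups have the same count of heavy atoms and the same kind of ring, and the change removes the triple bond and brings in two chlorines. No measurement at hand says why the number moves.

On these data alone, it remains open whether a single chlorine would give the same step, and how a methoxy group or an amine on this phenyl ring would compare. As far as these compounds go, it is also open whether the swap would have the same effect on the core of compound 2.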